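This account rests on a few compounds, and the source may have more. Where it says the series, first, only, none or still open, it means among the compounds named here.

Compound 1 `Sc1nnc(-c2ccc3c(c2)OCCO3)n1-c1ccccc1` has a hydrogen on its sulfur, and in a functional assay on SW 1116 cells (Homo sapiens) for antiproliferative activity, read by MTT assay, with a stated time of 24 h (on this read-out higher numbers stand for weaker inhibition and lower numbers for stronger inhibition), compound 1 gives 38400 nM. Compound 2 `c1ccc(CSc2nnc(-c3ccc4c(c3)OCCO4)n2-c2ccccc2)cc1` carries a benzyl on that sulfur and gives 7930 nM, while compound 3 `Clc1cccc(CSc2nnc(-c3ccc4c(c3)OCCO4)n2-c2ccccc2)c1` carries a 3-chlorobenzyl there and gives 10600 nM. Compound 3 therefore stands well under compound 1 on the numbers, and level with compound 2 once the usual scatter is allowed for.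

The next structure, compound 4 `COc1cccc(CSc2nnc(-c3ccc4c(c3)OCCO4)n2-c2ccccc2)c1`, keeps all of compound 3 except one group: methoxy in place of chloro on an aromatic carbon. This places methoxy in place of chloro on an aromatic carbon, giving a 3-methoxybenzyl on the sulfur. Among the measured compounds shown here, no measured compound carries a methoxy, so the guide is indirect. Adding a substituted or plain benzyl made a modest difference, a 4.8-fold lower number from compound 1 to compound 2 (0.69 log units; beyond the scatter) and a 3.6-fold lower number from compound 1 to compound 3 (0.56 log units; beyond the scatter). Changing the group at this ring position made almost none, a 1.3-fold higher number from compound 2 to compound 3 (0.13 log units; within the scatter). For the measured compounds named here, the one measured change at this position, in compound 3, thus stayed within the scatter, and no step beyond the scatter is foreseen in this assay. The expected step is small, a 1.1-fold lower number from compound 3 to compound 4 (0.05 log units; within the scatter). For compound 4 the estimated value is 9500 nM, with an expected range from 4500 nM to 20000 nM.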

Compound 4, half-maximal inhibitory concentration: 10100 nM
Beside the measured number, compound 4's estimate is 1.1-fold (0.03 log units) below it; the range from low to high includes it.
By their numbers in this assay, from the lowest: compounds 2, 4 and 3 (each within the scatter of the next); then compound 1.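

Methoxy brings one more heavy atom than chloro and a hydrogen-bond acceptor that chloro lacks, yet in this assay the swap gives a 1.0-fold lower number from compound 3 to compound 4 (0.02 log units; within the scatter) and the two groups read alike. Set against the plain benzyl, methoxy gives a 1.3-fold higher number from compound 2 to compound 4 (0.11 log units; within the scatter) and so also stays within the scatter, which means that hydrogen, chloro and methoxy at this ring position now form a set of three that cannot be told apart, where the earlier compounds offered only two. Among the compounds shown here, the one step here beyond the scatter remains the one on the sulfur, now seen with a third benzyl group as a 3.8-fold lower number from compound 1 to compound 4 (0.58 log units; beyond the scatter) and still modest, while nothing on hand explains why the ring groups read alike.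

From the compounds shown here alone, what stays open is whether an amine or a carboxylic acid at this ring position would also read like hydrogen, chloro and methoxy, or whether chloro and methoxy would read alike at another place on the same ring. Going by these compounds, a longer chain on the sulfur in place of the benzyl is equally open, so how far the step on the sulfur can go remains unknown.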